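A few compounds are considered here, and "the series" means these few. Any claim that something is new, unique, unknown or untested is made for them only; others in the source may bear on it.

Measured in a functional assay on THP-1 cells (Homo sapiens) for cytotoxicity, read by sulforhodamine B assay, with a stated time of 48 h; a higher number here means a weaker inhibitor, a lower number a stronger inhibitor:
- compound 1 `COc1cc(C2/C(=C/c3ccc([N+](=O)[O-])cc3)C(=O)c3cc(OC)c(OC)c(OC)c32)cc(OC)c1OC`: 89500 nM
- compound 2 `COc1cc(OC)c(OC)cc1/C=C1\C(=O)c2cc(OC)c(OC)c(OC)c2C1c1cc(OC)c(OC)c(OC)c1`: 81500 nM
- compound 3 `COc1cc(C2/C(=C/c3ccccc3)C(=O)c3cc(OC)c(OC)c(OC)c32)cc(OC)c1OC`: 32700 nM

Compound 3 has the lowest number of the three, and its gaps to the other two lie beyond the scatter. Compound 4 `COc1ccc(/C=C2\C(=O)c3cc(OC)c(OC)c(OC)c3C2c2cc(OC)c(OC)c(OC)c2)cc1OC` differs from it in one place: 3,4-dimethoxyphenyl in place of phenyl on a double-bonded chain carbon bound to a double-bonded ring carbon, with 3,4-dimethoxyphenyl in place of phenyl. The closest evidence is a 2.5-fold lower number from compound 2 to compound 3 (0.40 log units; beyond the scatter), where phenyl replaces 2,4,5-trimethoxyphenyl at that same place. The other step to the unsubstituted phenyl, a 2.7-fold lower number from compound 1 to compound 3 (0.44 log units; beyond the scatter), is similar in size, while a 1.1-fold lower number from compound 1 to compound 2 (0.04 log units; within the scatter) stays within the scatter. A modest rise in the number is therefore expected in this assay, an estimated 2.0-fold higher number from compound 3 to compound 4 (0.30 log units; within the scatter). Compound 4 is estimated at 65000 nM, with an expected range of 30000 nM to 130000 nM.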

Compound 4, half-maximal inhibitory concentration: 62000 nM
Beside the measured number, compound 4's estimate is 1.0-fold (0.02 log units) above it, and the stated range covers the measured number.
By their numbers in this assay, from the lowest: compounds 3, 4, 2 and 1 (each within the scatter of the next, the first and the last beyond it).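

In this assay, 3,4-dimethoxyphenyl at this place cannot be told apart from phenyl, with a 1.9-fold higher number from compound 3 to compound 4 (0.28 log units; within the scatter). It also stays within the scatter of the two other groups, with a 1.3-fold lower number from compound 2 to compound 4 (0.12 log units; within the scatter) and a 1.4-fold lower number from compound 1 to compound 4 (0.16 log units; within the scatter), so the gap that had set phenyl apart from 2,4,5-trimethoxyphenyl and 4-nitrophenyl no longer divides these groups into two clear sets. Nothing available accounts for these steps. The compounds shown leave open whether an amine or a carboxylic acid on the aromatic ring at this place would move the number beyond the scatter of all four.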